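Chloro removal across two isomeric dichloro cores

The source may report more compounds than this note shows. Statements on the series, on what has been measured and on what is new or still open speak of the compounds shown alone.

Three compounds share the chloromethylbenzyl group and differ in the halogenation and arrangement of the fused core. Compound 1 `ClCc1ccc(Cn2cnc3c(Cl)ncnc32)cc1` gives 1090 nM in a functional assay on TK-10 cells (Homo sapiens) for cytotoxicity, read by sulforhodamine B assay, with a stated time of 48 h; on this read-out higher numbers stand for weaker inhibition of growth and lower numbers for stronger inhibition of growth. Compound 2 `ClCc1ccc(Cn2cnc3nc(Cl)nc(Cl)c32)cc1` gives 120 nM in this assay, the lowest of the three numbers. Compound 3 `ClCc1ccc(Cn2cnc3c(Cl)nc(Cl)nc32)cc1` gives 6610 nM in this assay, the highest of the three. Compound 2 and compound 3 have the same atoms joined differently; the difference between the two cores is not broken down here.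

One change is measured within the set: hydrogen in place of chloro on an aromatic carbon. It gives a 6.1-fold lower number from compound 3 to compound 1 (0.78 log units; beyond the scatter).

Compound 4 `ClCc1ccc(Cn2cnc3ncnc(Cl)c32)cc1` is not yet measured. It is made from compound 2 by the same change, (hydrogen in place of chloro on an aromatic carbon), and its place line matches the earlier one word for word, so it is treated as the same change on a different core. For the measured compounds named here, only one measured example of it exists, and whether it transfers from the core of compound 3 to the core of compound 2 is untested.

The expectation for compound 4 in this assay is 25 nM, which means an estimated step of a 4.8-fold lower number from compound 2 to compound 4 (0.68 log units; beyond the scatter); this rests on compound 3 to compound 1 giving a 6.1-fold lower number from compound 3 to compound 1 (0.78 log units; beyond the scatter), applied to compound 2 at 120 nM. The estimated range for compound 4 is kept wide, expected to run from 8 nM to 90 nM, since a single prior step on another core carries little weight.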

Compound 4, concentration for 50% growth inhibition: 1470 nM
Compound 4: the middle estimate sits 59-fold (1.77 log units) below what was measured, and the stated range ends below it.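

Hydrogen in place of chloro on an aromatic carbon does not carry from one core to the other in this assay, as the two measured steps run in opposite directions: the same change on two cores in this assay, a 6.1-fold lower number (0.78 log units; beyond the scatter) from compound 3 to compound 1 and a 12-fold higher number (1.09 log units; beyond the scatter) from compound 2 to compound 4, 74-fold (1.87 log units) apart, beyond the scatter of two such steps

On the core of compound 2, the change gives a 12-fold higher number from compound 2 to compound 4 (1.09 log units; beyond the scatter), so on this core the chloro group goes with stronger inhibition of growth, whereas on the core of compound 3 its loss goes with stronger inhibition of growth. These two pairs show only that, for these compounds, the outcome of the change depends on the core; they give no reason for the reversal and do not predict the outcome on any third core, so a step measured on one core is a poor guide to the other in this series.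

The compounds shown leave open whether an amine, a methoxy group or a bromo group on the same aromatic carbon would follow the chloro group or the hydrogen on each core. They also leave open whether the reversal would persist if the chloromethyl group on the benzyl ring gave way to a plain methyl group or a hydroxymethyl group.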